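Removing a Phenyl Group from Two Related Cores

A few compounds are considered here, and "the series" means these few. Any claim that something is new, unique, unknown or untested is made for them only; others in the source may bear on it.

Compound 1, `CN1C[C@@H]2CN(c3cccnc3)C[C@@H]2C1`: 26 nM
Compound 2, `CN1C[C@@H]2CN(c3cncc(-c4ccccc4)c3)C[C@@H]2C1`: 51 nM
Compound 3, `c1ccc(-c2ccc(N3C[C@H]4CNC[C@H]4C3)nc2)cc1`: a limit of the assay, > 100000 nM

All three compounds were tested in an assay on membranes from brain for displacement of a labelled ligand from Neuronal acetylcholine receptor; alpha4/beta2 (Rattus norvegicus); on this read-out higher numbers stand for weaker inhibition and lower numbers for stronger inhibition. Compound 1 gives 26 nM and compound 2 gives 51 nM. For compound 3 the assay reports only a limit, > 100000 nM, and no number. Compound 2 becomes compound 1 through (hydrogen in place of phenyl on an aromatic carbon), a step of a 2.0-fold lower number from compound 2 to compound 1 (0.29 log units; within the scatter). Compound 4, `c1ccc(N2C[C@H]3CNC[C@H]3C2)nc1`, is not yet measured; it arises from compound 3 through (hydrogen in place of phenyl on an aromatic carbon). This is the same kind of change, not the same one: in compound 2 the phenyl sits meta to a group of 9 heavy atoms, in compound 3 para to a group of 8 heavy atoms. The difference between the cores of compound 2 and compound 3 is not broken down here. Because compound 3 sits at the limit of > 100000 nM in this assay, at which 1 of the 3 values shown sits, the earlier step of a 2.0-fold lower number from compound 2 to compound 1 (0.29 log units; within the scatter) can only loosely guide what follows. Compound 4 is expected near 20000 nM, between 500 nM and 100000 nM. For compound 4 that estimate means an expected step of an at least 5.0-fold lower number from compound 3 to compound 4 (0.69 log units; beyond the scatter).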

Compound 4, inhibition constant: 260 nM
Estimate against measurement, compound 4: 77-fold (1.89 log units) above; measured number below the stated range.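

In this assay, replacing the phenyl group with hydrogen gives an at least 380-fold lower number from compound 3 to compound 4 (2.58 log units; beyond the scatter), so this change does not carry over in size from one core to the other: the same change on two cores in this assay, a 2.0-fold lower number (0.29 log units; within the scatter) from compound 2 to compound 1 and an at least 380-fold lower number (2.58 log units; beyond the scatter) from compound 3 to compound 4, at least 190-fold (2.29 log units) apart, beyond the scatter of two such steps

Compound 3 has only a limit and no number, so this step has a lower bound and no exact size: the limit of > 100000 nM in this assay, at which 1 of the 4 values shown sits.

These two pairs show that the result of the change depended on the core, but they do not show which feature of the cores decides it, and two pairs set no rule for the whole series.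

As far as these compounds go, it remains open whether a methoxy group or a chlorine atom on the same aromatic carbon would behave more like the hydrogen or more like the phenyl group on each core. Also open, from the compounds shown here alone, is which part of the cores matters, a question that would need pairs whose cores differ in one place only.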